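Changing the Group on the Carbonyl of a Weak Inhibitor

The source may hold more compounds than are shown below. What is called first, only, known or untested is meant among the compounds shown, and "the series" means these compounds.

In a functional assay on BT-549 cells (Homo sapiens) for inhibition, read by sulforhodamine B assay, with a stated time of 48 h, tested at 10 uM (a lower number here means a stronger effect, a higher number a weaker effect of the compound at the concentration tested), compound 1 `COc1cc(Cl)cc(-c2nn(-c3cccc(NC(=O)c4ccc(Cl)c(Cl)c4)c3)cc2-c2ccncc2)c1` gives 85.2%, the highest of the three numbers and thus the weakest effect. Compound 3 `COc1cc(Cl)cc(-c2nn(-c3cccc(NC(=O)Nc4ccc(Cl)c(Cl)c4)c3)cc2-c2ccncc2)c1` gives 29.4%, while compound 2 `COc1cc(Cl)cc(-c2nn(-c3cccc(NC(=O)Nc4cc(C(F)(F)F)cc(C(F)(F)F)c4)c3)cc2-c2ccncc2)c1` gives 6.61%. Among the compounds with values here, the only step between compounds differing in one place, a number 55.8 percentage points lower from compound 1 to compound 3 (beyond the scatter), puts (3,4-dichlorophenyl)amino in place of 3,4-dichlorophenyl on the carbonyl carbon. Compound 4 `COc1cc(Cl)cc(-c2nn(-c3cccc(NC(=O)c4cccc(C(F)(F)F)c4)c3)cc2-c2ccncc2)c1` differs from compound 1 as follows: 3-(trifluoromethyl)phenyl in place of 3,4-dichlorophenyl on a carbonyl carbon. Within the data shown here, no measured step alters the group on the carbonyl carbon in this way, and compound 2 differs from compound 1 in two places, so it offers no separable guide. The expectation is therefore a step not beyond the scatter, a number 7.2 percentage points lower from compound 1 to compound 4 (within the scatter). Compound 4 is estimated at 78%, in the range 45% to 100%.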

Compound 4, a percentage reported as activity, at one concentration (the size of the read-out at that concentration, not a potency): 89.5%
Beside the measured number, compound 4's estimate is 11.5 percentage points below it; the range from low to high includes it.
By their numbers in this assay, from the lowest: compound 2; then compound 3; then compounds 1 and 4 (each within the scatter of the next).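

The step of a number 4.3 percentage points higher from compound 1 to compound 4 (within the scatter) in this assay shows that exchanging 3,4-dichlorophenyl for 3-(trifluoromethyl)phenyl on this carbonyl carbon makes no readable difference. The step of a number 60.1 percentage points higher from compound 3 to compound 4 (beyond the scatter) then joins the earlier one as a second large step, so both large steps at this position involve the amino nitrogen of (3,4-dichlorophenyl)amino, and neither substituted phenyl group alone gives a strong effect here. No measurement at hand explains these steps.

As far as these compounds go, how (3-(trifluoromethyl)phenyl)amino on the same carbonyl carbon would read remains open. So does the effect of a carboxylic acid or a morpholine on the phenyl ring.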